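The compounds below may be only part of what the source reports. "The series", "measured", "known", "first", "only" and "open" are said of these compounds alone.

Measured so far in a toxicity assay on microsomes from liver (Homo sapiens) for metabolic stability, read by LC-MS, using NADPH, tested at 1 uM; a higher number here means faster removal of the compound, a lower number slower removal:
Compound 1 `CCOc1ncc(-c2nc(C(F)(F)F)sc2N2CCN(C(=O)Cn3ccc4cccnc43)[C@H](C)C2)cn1` gives 316 mL.min-1.g-1
Compound 2 `COc1ncc(-c2nc(C(F)(F)F)sc2N2CCN(C(=O)Cn3nc(C)nc3C)[C@H](C)C2)cn1` gives < 10 mL.min-1.g-1 as a limit of the assay, not a number

Compound 2 stands on the limit of < 10 mL.min-1.g-1 in this assay, at which 1 of the 2 values shown sits, and so offers no exact starting value.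

Compound 3 `CCc1ncc(-c2nc(C(F)(F)F)sc2N2CCN(C(=O)Cn3nc(C)nc3C)[C@H](C)C2)cn1` keeps the rest of compound 2 but carries ethyl in place of methoxy on an aromatic carbon, between two ring nitrogen atoms and para to a large group ethyl in place of methoxy on an aromatic carbon in a change from 2-methoxypyrimidin-5-yl to 2-ethylpyrimidin-5-yl.

For the measured compounds named here, no measured pair isolates this change, so its size remains a judgement. Compound 1 at 316 mL.min-1.g-1 shows that high values occur among these compounds, though it differs in more than this one place. A modest rise in this assay is expected, with an estimated change of an at least 2.0-fold higher number from compound 2 to compound 3 (0.30 log units; that floor lies within the scatter) for this step. For compound 3 the expected value is 20 mL.min-1.g-1 with an estimated range of 10 mL.min-1.g-1 to 60 mL.min-1.g-1 in this measurement.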

Compound 3, intrinsic clearance in microsomes: 43 mL.min-1.g-1
Estimate against measurement, compound 3: 2.2-fold (0.33 log units) below; measured number inside the range.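

In this assay, for the compounds shown here, the earlier compounds differed in more than one place, and this pair is the first to isolate the 2-methoxypyrimidin-5-yl to 2-ethylpyrimidin-5-yl change: it brings an at least 4.3-fold higher number from compound 2 to compound 3 (0.63 log units; beyond the scatter) in a single place on the shared core. This position, on an aromatic carbon between two ring nitrogen atoms, therefore affects removal in this assay, with only the methoxy and ethyl groups changing there. The step is only a floor, since compound 2 stands on a limit of the assay and not on a number: the limit of < 10 mL.min-1.g-1 in this assay, at which 1 of the 3 values shown sits.

The compounds shown leave open how an amine or a longer chain at this position would read in this assay. They also leave open whether the same change would have a similar size with the other amide side chain of compound 1.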